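A few compounds are considered here, and "the series" means these few. Any claim that something is new, unique, unknown or untested is made for them only; others in the source may bear on it.

Measured so far in an assay on isolated protein for inhibition of aldehyde dehydrogenase 1A1 (Homo sapiens), read by spectrophotometry, tested at 10 uM; on this read-out lower numbers stand for less inhibition and higher numbers for more inhibition at the one concentration tested (going by the name of the read-out):
- compound 1 `O=C(C1CC1)N1CCN(Cc2nc3ccccc3n2Cc2ccccc2F)CC1` gives 40.7%
- compound 2 `CC(=O)N1CCN(Cc2nc3ccccc3n2Cc2cccc(C)c2)CC1` gives 70.3%
- compound 3 `O=C(C1CC1)N1CCN(Cc2nc3ccccc3n2Cc2ccc(F)cc2)CC1` gives 32.7%

Compound 2 stands highest of the three; compound 1 and compound 3 both lie beyond the scatter below it. Going by the values given here, the only single-point step measured, a number 8 percentage points lower from compound 1 to compound 3 (within the scatter), concerns the fluorophenyl and has no bearing on the carbonyl side of the molecule.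

Compound 4 `Cc1cccc(Cn2c(CN3CCN(C(=O)C4CCC4)CC3)nc3ccccc32)c1` arises from compound 2 by cyclobutyl in place of methyl on a carbonyl carbon. Among the compounds with values here, compound 1 and compound 3 give lower numbers than compound 2, but they differ from compound 2 in more than one place, so no measured step isolates the present change. A moderate fall is expected rather than none, a number 15.3 percentage points lower from compound 2 to compound 4 (beyond the scatter), with wide uncertainty. For compound 4 the estimate in this assay is 55%, range 30% to 78%.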

Compound 4, a percentage reported as inhibition, at one concentration (the size of the read-out at that concentration, not a potency): 69.1%
Beside the measured number, compound 4's estimate is 14.1 percentage points below it; the range from low to high includes it.
By their numbers in this assay, from the lowest: compounds 3 and 1 (each within the scatter of the next); then compounds 4 and 2 (each within the scatter of the next).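

In this assay, cyclobutyl in place of methyl on a carbonyl carbon gives a number 1.2 percentage points lower from compound 2 to compound 4 (within the scatter). At this position, with the rest of compound 2 unchanged, going from 1 heavy atom to 4 heavy atoms and adding a four-membered ring of carbon only produces no step beyond the scatter. No available evidence accounts for this result.

Open, going by these compounds, is whether a phenyl ring, a longer chain or a primary amine on the same carbonyl carbon would fit this result. The compounds shown also isolate no step linking compound 4 to compound 1 or compound 3.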